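The source may report more compounds than this note shows. Statements on the series, on what has been measured and on what is new or still open speak of the compounds shown alone.

In a functional assay on HeLa cells (Homo sapiens) for antiproliferative activity (a higher number here means a weaker inhibitor, a lower number a stronger inhibitor), compound 2 `C/C(=N\Nc1nc(-c2ccc(C)cc2)cs1)c1cc2ccccc2o1` gives 14300 nM. For the measured compounds named here, the only other measured compound, compound 1 `C/C(=N\Nc1nc(-c2ccc(Cl)cc2)cs1)c1cc2ccccc2o1`, gives 26600 nM in this assay, and the two lie within the scatter of each other, the change being a 1.9-fold lower number from compound 1 to compound 2 (0.27 log units; within the scatter). Compound 3 `COc1ccc(-c2csc(N/N=C(\C)c3cc4ccccc4o3)n2)cc1` carries methoxy in place of methyl on an aromatic carbon. Going by the values given here, no measured step exchanges methyl for methoxy, and the one step that alters the same aromatic carbon stayed within the scatter, so no step beyond the scatter is expected, and the estimate amounts to a 1.0-fold lower number from compound 2 to compound 3 (0.01 log units; within the scatter). Compound 3 is thus expected to give about 14000 nM in this assay, within a range from 5000 nM to 40000 nM.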

Compound 3, half-maximal inhibitory concentration: 18700 nM
Compound 3: the middle estimate sits 1.3-fold (0.13 log units) below what was measured; low and high end bracket the measured number.
By their numbers in this assay, from the lowest: compounds 2, 3 and 1 (each within the scatter of the next).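

With methoxy on this aromatic carbon, both new steps stay within the scatter: a 1.3-fold higher number from compound 2 to compound 3 (0.12 log units; within the scatter), and a 1.4-fold lower number from compound 1 to compound 3 (0.15 log units; within the scatter). Chloro, methyl and methoxy at this place thus cannot be told apart in this assay, even though methoxy is the only one of the three counted with a hydrogen-bond acceptor. Nothing available explains this lack of separation.

As far as these compounds go, whether an amine or a carboxylic acid here would separate from these three remains open. So does whether a change elsewhere on the shared core would do so.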